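Swapping the Acyl Group of Compound 1

The source may hold more compounds than are shown below. What is called first, only, known or untested is meant among the compounds shown, and "the series" means these compounds.

Three compounds have been measured in a functional assay on Z-138 cells (Homo sapiens) for inhibition, read by luminescence and CellTiter-Glo, with a stated time of 72 h; on this read-out higher numbers stand for weaker inhibition and lower numbers for stronger inhibition:

Compound 1, `O=C(CCl)N1CCCC(n2nc(-c3ccc(Oc4ccccc4)cc3)cc2CO)C1`: 400 nM
Compound 2, `C=CC(=O)Nc1cccc(Cn2nc(-c3ccc(Oc4ccccc4)cc3)cc2C(=O)OCC)c1`: 7800 nM
Compound 3, `C/C=C/C(=O)Nc1cccc(Cn2nc(-c3ccc(Oc4ccccc4)cc3)cc2CO)c1`: 5700 nM

Compound 1 stands at the lowest number of the three. Compound 3 lies higher by a margin beyond the usual scatter, and compound 2 higher still. No two of these measured compounds differ in only one place, so none of these gaps can be assigned to a single structural change.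

Compound 4, `C/C=C/C(=O)N1CCCC(n2nc(-c3ccc(Oc4ccccc4)cc3)cc2CO)C1`, has not yet been measured. It differs from compound 1 by prop-1-en-1-yl in place of chloromethyl on a carbonyl carbon. Compound 3 carries a prop-1-en-1-yl carbonyl as well, on a different scaffold, and gives 5700 nM, but the other differences between compound 3 and compound 1 prevent any clean reading of that number.

For this assay the step of a 3.0-fold higher number from compound 1 to compound 4 (0.48 log units; beyond the scatter) is expected to go toward a higher number, by a moderate amount beyond the scatter. Compound 4 is therefore estimated at 1200 nM, with a plausible range from 400 nM to 4000 nM.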

Compound 4, half-maximal inhibitory concentration: 51100 nM
The estimate for compound 4 lay 43-fold (1.63 log units) below the measured number; measured number above the stated range.
By their numbers in this assay, from the lowest: compound 1; then compounds 3 and 2 (each within the scatter of the next); then compound 4.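

Going by these compounds alone, this is the first pair here that differs in only one place, so a gap can now be tied to a single change: in this assay, prop-1-en-1-yl in place of chloromethyl on a carbonyl carbon gives a 130-fold higher number from compound 1 to compound 4 (2.11 log units; beyond the scatter) on an otherwise unchanged structure. The step is large, which shows that on the core of compound 1 the read-out depends strongly on which of these two groups the carbonyl carries. No supporting measurement accounts for the size of this step.

On these data alone, with only these two groups compared at this position, it remains open how an ethenyl or a plain methyl on the same carbonyl carbon would read on this core. As far as these compounds go, whether a chloromethyl carbonyl would shift the number on the core of compound 3 also remains open.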